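The source may report more compounds than this note shows. Statements on the series, on what has been measured and on what is new or still open speak of the compounds shown alone.

Working notes on the series. In a functional assay on HCC 2998 cells (Homo sapiens) for inhibition, read by sulforhodamine B assay, with a stated time of 48 h (a higher number here means a weaker inhibitor of growth, a lower number a stronger inhibitor of growth), compound 1, the compound `COc1cc(-c2cc(/C=C/C(=O)c3ccc(N)cc3)[nH]n2)cc(OC)c1OC`, gives 2010 nM. Among the measured compounds shown here, the only other compound with a number is compound 2, the compound `COc1ccc(-c2cc(/C=C/C(=O)c3ccc(OC)c(OC)c3)[nH]n2)cc1`, which in this assay gives 2020 nM. Compound 1 therefore holds the lowest of the two numbers, but its nearest neighbour, compound 2, sits within the scatter of it, so no order between compound 1 and compound 2 can be read from these two values.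

The next compound is compound 3, the compound `COc1cc(-c2cc(/C=C/C(=O)c3ccc(Cl)c(Cl)c3)[nH]n2)cc(OC)c1OC`, not yet measured in this assay. It departs from compound 1 at the carbonyl carbon: 3,4-dichlorophenyl in place of 4-aminophenyl on a carbonyl carbon. For the measured compounds named here, no step between two measured compounds covers this kind of change, so there is no measured step to lean on. Given that compound 1 and compound 2 sit close together, the step from compound 1 to compound 3 is expected to be modest, with no clear direction, and most likely not far beyond the scatter: a 1.2-fold higher number from compound 1 to compound 3 (0.09 log units; within the scatter). For compound 3 the expected value in this assay is 2500 nM, within a range from 600 nM to 10000 nM.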

Compound 3, concentration for 50% growth inhibition: 9560 nM
Beside the measured number, compound 3's estimate is 3.8-fold (0.58 log units) below it; low and high end bracket the measured number.
By their numbers in this assay, from the lowest: compounds 1 and 2 (each within the scatter of the next); then compound 3.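

Among the compounds shown here, the group on the carbonyl carbon is the first place where a single change gives a readable step: in this assay, 3,4-dichlorophenyl in place of 4-aminophenyl gives a 4.8-fold higher number from compound 1 to compound 3 (0.68 log units; beyond the scatter) with the rest of compound 1 unchanged. This position therefore does not tolerate every aryl group equally in this assay, something compounds 1 and 2 could not show, as they differ in more than one place and their values lie within the scatter of each other. The change removes the amine and brings in two chlorine atoms in one move, and no supporting data are available to say which of these, if either, accounts for the step.

A single step cannot separate the two parts of the exchange, so 4-chlorophenyl, 3,4-dimethoxyphenyl or 4-hydroxyphenyl on the same carbonyl carbon of the core of compound 1 would be needed to show how the number follows the group. From the compounds shown here alone, whether the step holds when the 3,4-dichlorophenyl group sits on the core of compound 2 also remains open.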